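Bromothiophene placement and removal in the shared core series

This account rests on a few compounds, and the source may have more. Where it says the series, first, only, none or still open, it means among the compounds named here.

Compound 1 `CC(C)C[C@@H]1C(=O)N[C@H](C2Cc3ccccc3C2)C(=O)N1[C@@H](C(=O)NC(C)C)c1ccc(Br)s1`: 2 nM
Compound 2 `CC(C)C[C@@H]1C(=O)N[C@H](C2Cc3ccccc3C2)C(=O)N1[C@@H](C(=O)NC(C)C)c1cc(Br)cs1`: 1 nM

Both measured compounds share the core and differ only in the bromo position on the thiophene. Within the data shown here, in an assay on isolated protein for binding affinity to Oxytocin receptor (Homo sapiens) (a higher number here means a weaker inhibitor, a lower number a stronger inhibitor), compound 2 gives 1 nM, and the only step to it, a 2.0-fold lower number from compound 1 to compound 2 (0.30 log units; within the scatter), is within the scatter, so compound 2 sits level with compound 1 rather than apart from it.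

Compound 3 `CC(C)C[C@@H]1C(=O)N[C@H](C2Cc3ccccc3C2)C(=O)N1[C@@H](C(=O)NC(C)C)c1cccs1` is the unmeasured member: the change from compound 2 is hydrogen in place of bromo on an aromatic carbon, a hydrogen in place of bromo on an aromatic carbon. No measured step removes the bromine; the single step shown, from compound 1 to compound 2, only moves it around the ring and stays within the scatter, so it bears on compound 3 only indirectly, by showing that the ring tolerates either placement without a shift beyond the scatter.

Among the measured compounds shown here, with no direct precedent, compound 3 is expected to lose some affinity on removing the bromine, a step of a 4.0-fold higher number from compound 2 to compound 3 (0.60 log units; beyond the scatter), with the range kept wide. The estimate for compound 3 in this assay is 4 nM, between 1 nM and 20 nM.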

Compound 3, inhibition constant: 6.31 nM
The estimate for compound 3 lay 1.6-fold (0.20 log units) below the measured number; the range from low to high includes it.
By their numbers in this assay, from the lowest: compounds 2 and 1 (each within the scatter of the next); then compound 3.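

In this assay, among these compounds, the change to hydrogen is the first at this position to go beyond the scatter, with a 6.3-fold higher number from compound 2 to compound 3 (0.80 log units; beyond the scatter) and a 3.2-fold higher number from compound 1 to compound 3 (0.50 log units; beyond the scatter), whereas moving the bromine around the ring, a 2.0-fold lower number from compound 1 to compound 2 (0.30 log units; within the scatter), stayed within it. Both steps out of the bromo compounds are modest and point the same way, so bromine at either placement goes with a lower number than the unsubstituted thiophen-2-yl, yet compound 3 still holds 6.31 nM and the bromine is a modest gain rather than a requirement for affinity in this series. Nothing available accounts for the size of this step.

Open, from the compounds shown here alone, is whether the gain belongs to bromine itself or would also appear with chloro, methyl, methoxy or a nitrile on this aromatic carbon, and whether a larger group such as phenyl or a polar one such as a carboxylic acid or an amine is accepted there. Also open, going by these compounds, is whether the same step would hold if the isopropyl amide or the leucine-type isobutyl side chain of the shared core were replaced, for example by a cyclopropyl amide or a shorter chain.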